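This account rests on a few compounds, and the source may have more. Where it says the series, first, only, none or still open, it means among the compounds named here.

Values in a functional assay on P388 cells (Mus musculus) for antiproliferative activity, with a stated time of 72 h; on this read-out lower numbers stand for an effect already at smaller amounts and higher numbers for an effect only at larger amounts of compound:
Compound 1 `Cc1cn([C@@H]2O[C@H](CO)[C@@H](CF)[C@H]2O)c(=O)[nH]c1=O`: > 100 uM
Compound 2 `Cc1cn([C@@H]2O[C@H](CO)[C@@H](CN)[C@H]2O)c(=O)[nH]c1=O`: > 100 uM
Compound 3 `Cc1cn([C@@H]2O[C@H](CO)[C@@H](CO)[C@@H]2O)c(=O)[nH]c1=O`: > 100 uM

All three entries are limits and not numbers, so the limit of > 100 uM in this assay, at which 3 of the 3 values shown sit, describes the whole set. Compound 3 therefore has no numerical position in this assay.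

Compound 4 `Cc1cn([C@@H]2O[C@H](CO)[C@@H](CO)[C@H]2O)c(=O)[nH]c1=O` differs from compound 3 as follows: the two compounds have the same atoms and bonds and differ only in configuration as drawn: 1 of 4 stereo elements differ; a stereocentre at a saturated ring carbon is drawn S in compound 3 and R in compound 4.

For the measured compounds named here, the only measured step, a step that the two limits leave unreadable from compound 1 to compound 2, lies at another place and concerns no change of configuration, so it gives no size to carry over. No step beyond the usual scatter is expected, and the estimate is a step that the limit leaves unreadable from compound 3 to compound 4. The expectation rests on compound 3, a limit at > 100 uM. Compound 4 is estimated at 150 uM, with an expected range of 60 uM to 400 uM.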

Compound 4, concentration for half-maximal effect: > 100 uM
Compound 4 was reported as a limit; the forecaster's own chance of this, stated with the estimate: 85%; the middle value does not contradict the limit.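

In this assay no step can be read among compound 1, compound 2, compound 3 and compound 4, since each stands only as a limit: the limit of > 100 uM in this assay, at which 4 of the 4 values shown sit.

The compounds shown leave open whether fluoro, amino, hydroxy or the drawn configuration makes any difference on this read-out.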